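The source may report more compounds than this note shows. Statements on the series, on what has been measured and on what is new or still open speak of the compounds shown alone.

Measured so far in an ADME assay on Raji cells (Homo sapiens) for cytotoxicity, with a stated time of 72 h; a higher number here means that more compound is needed for the effect, a lower number that less compound is needed:
Compound 1 `Cc1cc(NC(=O)Nc2cccc(C(N)=O)c2)c2ccccc2n1`: > 25000 nM, a limit
Compound 2 `Cc1cc(NC(=O)Nc2ccccc2C(C)(C)C)c2ccccc2n1`: > 25000 nM, a limit
Compound 3 `COC(=O)c1cccc(NC(=O)Nc2cc(C)nc3ccccc23)c1`: 26000 nM

Compound 2 receives no number from the assay, only the limit > 25000 nM. It is not alone in this, as the set is marked by the limit of > 25000 nM in this assay, at which 2 of the 3 values shown sit. Going by the values given here, compound 3 gives 26000 nM, the only actual number among the three.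

Compound 4 `Cc1cc(NC(=O)Nc2ccccc2C(F)(F)F)c2ccccc2n1` keeps the shared core of compound 2 and changes in one place: trifluoromethyl in place of tert-butyl on an aromatic carbon. Trifluoromethyl stands in place of tert-butyl on an aromatic carbon of a six-membered aromatic ring of carbon only, ortho to a large group.

Among the compounds with values here, no measured step covers this exchange. Within the data shown here, the one step available, a step that the limit leaves unreadable from compound 1 to compound 3, concerns a different change, methoxy in place of amino on a carbonyl carbon, and it offers no size to carry over. Among the measured compounds shown here, the expectation therefore rests on the values themselves, with compound 3 at 26000 nM as the only number, and no step beyond the scatter is expected in this assay. The expected step is a step that the limit leaves unreadable from compound 2 to compound 4, and it may well be unreadable if the assay again reports only a limit. For compound 4 the estimated value is 26000 nM, with an expected range from 12000 nM to 50000 nM.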

Compound 4, half-maximal effective concentration: > 25000 nM
Compound 4: only a limit was reported; the forecaster's own chance of this, stated with the estimate: 70%; the middle value does not contradict the limit.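

In this assay compound 4 gives > 25000 nM as a limit, not a number. Compound 2 gives > 25000 nM as a limit too, so no step can be read between compound 2 and compound 4. The compounds shown leave open whether trifluoromethyl in place of tert-butyl changes the result at all, and one limit dominates the set: the limit of > 25000 nM in this assay, at which 3 of the 4 values shown sit.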